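The source may hold more compounds than are shown below. What is called first, only, known or untested is meant among the compounds shown, and "the series" means these compounds.

Compound 3 `O=C(O)c1csc(SCCN2C(=O)CC[C@@H]2/C=C/[C@@H](O)Cc2cccc(-c3nc4ccccc4o3)c2)n1` belongs to a small set of three compounds studied in an assay on CHO cells for displacement of a labelled ligand from prostaglandin E2 receptor EP1 subtype (Mus musculus), read by scintillation counting, with a stated time of 20 min; on this read-out lower numbers stand for stronger inhibition and higher numbers for weaker inhibition. Compound 1 `O=C(O)CCCSCCN1C(=O)CC[C@@H]1/C=C/[C@@H](O)Cc1cccc(N2Cc3ccccc3C2)c1` gives 7100 nM in this assay. For compound 2 `O=C(O)CCCSCCN1C(=O)CC[C@@H]1/C=C/[C@@H](O)Cc1cccc(OCc2ccncc2)c1` this assay reports only a limit, > 10000 nM. For compound 3 this assay likewise reports only a limit, > 10000 nM. Compound 3 therefore stands at the limit of > 10000 nM in this assay, at which 2 of the 3 values shown sit, with no number of its own. Within the data shown here, the single measured step, an at least 1.4-fold higher number from compound 1 to compound 2 (0.14 log units; that floor lies within the scatter), concerns a different place on the shared core and has a floor so small that it tells nothing about direction.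

Compound 4 `Cc1cccc2oc(-c3cccc(C[C@H](O)/C=C/[C@H]4CCC(=O)N4CCSc4nc(C(=O)O)cs4)c3)nc12` differs from compound 3 by methyl in place of hydrogen on an aromatic carbon, in words methyl in place of hydrogen on an aromatic carbon. Among the measured compounds shown here, no measured step touches this position, and the only step on record is itself within the scatter, so there is no ground to expect a change beyond the scatter in this assay. The step is expected to read a step that the limit leaves unreadable from compound 3 to compound 4, meaning compound 4 most likely stays at the limit as well. Compound 4 is therefore estimated to give 15000 nM in this assay. For compound 4 the expected range runs from 5000 nM to 50000 nM.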

Compound 4, inhibition constant: 7700 nM
For compound 4 the middle estimate is 1.9-fold (0.29 log units) above the measured one; measured number inside the range.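

Among these compounds, compound 4 gives a real number in this assay, 7700 nM, so this position on the 1,3-benzoxazol-2-yl group can now be read, which no earlier compound allowed. Methyl in place of hydrogen here is recorded as an at least 1.2-fold lower number from compound 3 to compound 4 (0.11 log units; that floor lies within the scatter), a result that fits a small change as well as a large one and does not choose between them. The true size of the step stays hidden because compound 3 has no number of its own, only a limit: the limit of > 10000 nM in this assay, at which 2 of the 4 values shown sit.

On these data alone, whether methyl is special in this place remains open, and so does how chlorine, methoxy or ethyl on the same aromatic carbon would read in this assay. As far as these compounds go, it is equally open whether methyl on another carbon of that six-membered ring would give a number or stay at the limit.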